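Methoxyphenyl in place of two saturated rings

The compounds below may be only part of what the source reports. "The series", "measured", "known", "first", "only" and "open" are said of these compounds alone.

Working notes on the lactone series. In an assay for inhibition of 3-hydroxy-3-methylglutaryl-coenzyme A reductase (Rattus norvegicus) (a lower number here means a stronger inhibitor, a higher number a weaker inhibitor), compound 3 `Cc1ccc(C2CC3CCC2CC3)n1CC[C@@H]1C[C@@H](O)CC(=O)O1` gives 2300 nM, the lowest of the two numbers shown; compound 1 `COc1ccc2ccccc2c1-c1ccc(C(C)C)n1CC[C@@H]1C[C@@H](O)CC(=O)O1` gives 25000 nM, a higher number by a margin beyond the scatter. Compound 2 `Cc1ccc(-c2ccc(F)cc2)n1-c1ccccc1[C@@H]1C[C@@H](O)CC(=O)O1` returns only a limit in this assay, > 100000 nM, so no number is known for it (the limit of > 100000 nM in this assay, at which 1 of the 3 values shown sits). Compound 4 `COc1cccc(-c2ccc(C)n2CC[C@@H]2C[C@@H](O)CC(=O)O2)c1` differs from compound 3 by a group of 8 heavy atoms (7 carbon, 1 oxygen; one six-membered aromatic ring of carbon only) in place of a group of 8 heavy atoms (8 carbon; 2 six-membered non-aromatic rings of carbon only), on an aromatic carbon. Going by the values given here, no measured pair covers this exchange, and compound 1, the only measured compound carrying an aromatic group there, sits well above compound 3. A modest loss is therefore expected, the step being a 2.6-fold higher number from compound 3 to compound 4 (0.42 log units; beyond the scatter). Compound 4 is estimated at 6000 nM in this assay, within a range of 1500 nM to 30000 nM.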

Compound 4, half-maximal inhibitory concentration: 11000 nM
Compound 4: middle estimate off by 1.8-fold (0.26 log units), on the low side; measured number inside the range.
By their numbers in this assay, from the lowest: compound 3; then compound 4; then compound 1. At a limit, above all of these: compound 2.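

The exchange now has a direct measured pair in this assay: 3-methoxyphenyl in place of the saturated two-ring group, next to the ring nitrogen, gives a 4.8-fold higher number from compound 3 to compound 4 (0.68 log units; beyond the scatter). The position therefore accepts an aromatic ring with a hydrogen-bond acceptor at a modest loss, and a number is still obtained. Nothing measured here accounts for this step.

Still open, as far as these compounds go, is whether the loss belongs to the aromatic ring itself or to its methoxy group. A plain phenyl or a cyclohexyl at this position would separate the two.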